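Swapping the Aromatic Group on a Shared Core

This account rests on a few compounds, and the source may have more. Where it says the series, first, only, none or still open, it means among the compounds named here.

Compound 1 `NS(=O)(=O)c1ccc(Nc2nc(N/N=C/c3ccc(C(F)(F)F)cc3)nc(Nc3ccccc3)n2)cc1` and compound 2 `Cc1nn(-c2ccccc2)cc1/C=N/Nc1nc(Nc2ccccc2)nc(Nc2ccc(S(N)(=O)=O)cc2)n1` share one core and differ only in the aromatic group joined to the carbon with a double bond to nitrogen. In a functional assay on NCI-H522 cells (Homo sapiens) for inhibition, read by sulforhodamine B assay, with a stated time of 48 h (a lower number here means that less compound is tolerated, a higher number that more compound is tolerated), compound 1 gives 87100 nM. Compound 2 reaches only the limit of this assay, > 100000 nM, so no exact number is known for it; it sits at the limit of > 100000 nM in this assay, at which 1 of the 2 values shown sits. The step of an at least 1.1-fold higher number from compound 1 to compound 2 (0.05 log units; that floor lies within the scatter) thus shows no change beyond the scatter.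

Compound 3 `NS(=O)(=O)c1ccc(Nc2nc(N/N=C/c3ccccn3)nc(Nc3ccccc3)n2)cc1` carries the change (pyridin-2-yl in place of 3-methyl-1-phenyl-1H-pyrazol-4-yl on a carbon with a double bond to nitrogen). Within the data shown here, the one measured step at this same position, the one just described, stayed within the scatter, and it is the only evidence that bears on this new swap. Compound 3 is therefore expected to land close to compound 2, with an expected step of a number no higher from compound 2 to compound 3 (the limit leaves the size open). The estimate for compound 3 is 100000 nM, expected to fall between 40000 nM and 250000 nM.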

Compound 3, concentration lethal to 50% of the cells: > 100000 nM
Compound 3: a limit, no number; the forecaster's own chance of this, stated with the estimate: 50%; the middle value lies on the limit itself.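

Replacing the two-ring 3-methyl-1-phenyl-1H-pyrazol-4-yl with the single-ring pyridin-2-yl again gives no number in this assay, only a limit for compound 3: the limit of > 100000 nM in this assay, at which 2 of the 3 values shown sit.

Measured against the 4-(trifluoromethyl)phenyl group, the new group gives an at least 1.1-fold higher number from compound 1 to compound 3 (0.05 log units; that floor lies within the scatter), so neither readable step at this position goes beyond the scatter. The step between the two compounds at the limit cannot be read, so these two groups cannot be ranked against each other.

Going by these compounds, it remains open whether any group on this carbon can bring the number clearly lower than that of compound 1. A phenyl ring carrying an amine or a carboxylic acid at this place would test a different kind of group, and only a compound measured below the limit would give a step of readable size.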